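A Bromophenyl Swap Near the Limit of the Assay

A few compounds are considered here, and "the series" means these few. Any claim that something is new, unique, unknown or untested is made for them only; others in the source may bear on it.

Measured in a toxicity assay on THP-1 cells (Homo sapiens) for inhibition; on this read-out higher numbers stand for lower toxicity in this test and lower numbers for higher toxicity in this test:
Compound 1 `Cn1c(-c2ccc(F)cc2)cnc1NC(=O)c1ccc(F)cc1`: > 100000 nM (a limit)
Compound 2 `COc1ccc(-c2cnc(NC(=O)c3ccc(F)cc3)n2C)cc1`: >= 50000 nM (a limit)

Compound 2 has no exact number, since its >= 50000 nM is a limit. The only other result, for compound 1, is a limit too, so neither compound gives a firm starting point.

Compound 3 `Cn1c(-c2ccccc2Br)cnc1NC(=O)c1ccc(F)cc1` keeps the shared core and the amide side of compound 2, and carries 2-bromophenyl in place of 4-methoxyphenyl (2-bromophenyl in place of 4-methoxyphenyl on an aromatic carbon). For the measured compounds named here, the one measured step, a step that the two limits leave unreadable from compound 1 to compound 2, swapped a group on the phenyl ring that changes here. Its size cannot be read, so it offers no measured guide to how far the new change might move the result. On that basis, compound 3 is expected to stay in the same low-toxicity region as the two measured compounds, quite possibly reported only as a limit again. The estimated step is a step that the limit leaves unreadable from compound 2 to compound 3, with no direction that the data can support. For compound 3 the expected value is 70000 nM, with an estimated range from 25000 nM to 150000 nM.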

Compound 3, half-maximal cytotoxic concentration: > 100000 nM
Compound 3: no number, only a limit (the forecaster's own chance of this, stated with the estimate: 75%); middle value at least 1.4-fold (0.15 log units) from the limit.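

In this assay compound 3 gives > 100000 nM, which is a limit and not a number. For the compounds shown here, with only limits for compound 1, compound 2 and compound 3, no step between them can be read. The compounds shown leave open whether 4-fluorophenyl, 4-methoxyphenyl and 2-bromophenyl differ at all in this assay.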